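Chain Extension on a Dimethylarginine Dimethylaminohydrolase Inhibitor

The source may report more compounds than this note shows. Statements on the series, on what has been measured and on what is new or still open speak of the compounds shown alone.

Measured compounds:
compound 1, `COCC(=N)NCCC[C@H](N)C(=O)O`: 73000 nM
compound 2, `COCC(=N)NCCCCN`: 983000 nM

In an assay on cells for inhibition of N(G),N(G)-dimethylarginine dimethylaminohydrolase 1 (Homo sapiens), with a stated time of 30 min (on this read-out lower numbers stand for stronger inhibition and higher numbers for weaker inhibition), compound 1 gives 73000 nM, the lowest of the two numbers recorded. Among the measured compounds shown here, compound 2 gives 983000 nM in this assay, and the single measured step, a 13-fold higher number from compound 1 to compound 2 (1.13 log units; beyond the scatter), comes from hydrogen in place of carboxy on a saturated chain carbon bound to an amine nitrogen and a saturated chain carbon.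

Compound 3, `COCCCC(=N)NCCC[C@H](N)C(=O)O`, differs from compound 1 in another part of the molecule: 2-methoxyethyl in place of methoxy on a saturated chain carbon bound to a carbon with a double bond to nitrogen. For the measured compounds named here, no measured step touches this position; the one step known concerns the carboxy group and says nothing about lengthening the chain that carries the methoxy. With nothing to weigh either way, the expectation for this assay is a step within the scatter, no change at the digits printed from compound 1 to compound 3 (within the scatter), though the range is set wide to reflect that lack of evidence. Compound 3 is therefore estimated at 73000 nM, between 20000 nM and 260000 nM.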

Compound 3, inhibition constant: 156000 nM
Beside the measured number, compound 3's estimate is 2.1-fold (0.33 log units) below it; measured number inside the range.
By their numbers in this assay, from the lowest: compound 1; then compound 3; then compound 2.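

Replacing methoxy with 2-methoxyethyl on a saturated chain carbon bound to a carbon with a double bond to nitrogen gives, in this assay, a 2.1-fold higher number from compound 1 to compound 3 (0.33 log units; beyond the scatter). This shows that the number responds to a change at this position, which the earlier step, confined to the carboxy group, could not reveal. The available data offer no measurement that accounts for this shift.

Among the compounds shown here, with only one change at this position, it remains open whether a longer chain, such as 3-methoxypropyl, would continue in the same direction, or whether an ethyl group or a hydroxyl group in place of the methoxy would give a similar number. From the compounds shown here alone, it is also open whether 2-methoxyethyl would produce a step of similar size in compound 2, which carries hydrogen in place of the carboxy group.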